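The source may hold more compounds than are shown below. What is called first, only, known or untested is meant among the compounds shown, and "the series" means these compounds.

Measured compounds in a functional assay on the whole organism for inhibition, with Brassica rapa subsp. chinensis as the target, with a stated time of 3 days, tested at 100 ppm; a higher number here means more inhibition of growth at the concentration tested, a lower number less inhibition of growth:
compound 1 `CC(C)OC(=O)/C=C/c1ccccc1` gives 2%
compound 2 `CC(C)(C)NC(=O)/C=C/c1ccccc1` gives 34%
compound 3 `CCC(C)NC(=O)/C=C/c1ccccc1` gives 56%

Compound 3 stands highest of the three in this assay, with compound 2 nearest and compound 1 furthest; both gaps are beyond the scatter.

Compound 4 `CCCOC(=O)/C=C/c1ccccc1` differs from compound 3 by propoxy in place of (sec-butyl)amino on a carbonyl carbon.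

Among the measured compounds shown here, the steps that bear on this change are a number 54 percentage points higher from compound 1 to compound 3 (beyond the scatter) and a number 32 percentage points higher from compound 1 to compound 2 (beyond the scatter), both large; compound 1 with isopropoxy on the carbonyl carbon sits at the bottom of the set. Compound 4 returns to an ester with propoxy in its place, so a large step downward in this assay is expected, roughly reversing the step from compound 1 to compound 3. The expected step is a number 51 percentage points lower from compound 3 to compound 4 (beyond the scatter). For compound 4 the estimate is 5%, in the range 0% to 20%.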

Compound 4, percent growth inhibition at one concentration: 31%
For compound 4 the middle estimate is 26 percentage points below the measured one; measured number outside the range, above it.
By their numbers in this assay, from the lowest: compound 1; then compounds 4 and 2 (each within the scatter of the next); then compound 3.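

In this assay propyl in place of isopropyl gives a number 29 percentage points higher from compound 1 to compound 4 (beyond the scatter) and so the ester alone does not fix the low reading of compound 1. Propoxy in place of (sec-butyl)amino on a carbonyl carbon gives a number 25 percentage points lower from compound 3 to compound 4 (beyond the scatter) while propoxy in place of (tert-butyl)amino gives a number 3 percentage points lower from compound 2 to compound 4 (within the scatter) and so the amides shown do not stand uniformly above this ester. Nothing available accounts for these differences.

Still open, from the compounds shown here alone, is how (propyl)amino would compare with propoxy on this carbonyl carbon. Going by these compounds, the readings for butoxy or a free carboxylic acid there also remain open.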